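The compounds below may be only part of what the source reports. "The series", "measured", "known", "first", "only" and "open" are said of these compounds alone.

Measured so far in a physicochemical assay for acid dissociation:
compound 1, `c1ccc(CCc2ccc3c(NCCCNCc4ccco4)ccnc3c2)cc1`, which gives 9.47
compound 2, `c1coc(CNCCCNc2ccnc3cc(CC4CCCCC4)ccc23)c1`, which gives 9.47
compound 3, `COc1cccc(CNCCCNc2ccnc3cc(CCc4ccccc4)ccc23)c1O`, which gives 9.47

Compound 1 and compound 2 differ in one place, (cyclohexyl in place of benzyl on a saturated chain carbon bound to an aromatic carbon), and the step of no change at the digits printed from compound 1 to compound 2 (within the scatter). Compound 3 has the core of compound 1 changed at one spot, (2-hydroxy-3-methoxyphenyl in place of furan-2-yl on a saturated chain carbon bound to an amine nitrogen). Compound 4, `COc1cccc(CNCCCNc2ccnc3cc(CC4CCCCC4)ccc23)c1O`, is not yet measured; it differs from compound 3 by cyclohexyl in place of benzyl on a saturated chain carbon bound to an aromatic carbon, at a place described in the same words as before, so this is the same change made on the other core. Going by the values given here, the only guide is the step of no change at the digits printed from compound 1 to compound 2 (within the scatter). On that basis the step of no change at the digits printed from compound 3 to compound 4 (within the scatter) is expected to be just as small. Compound 4 is therefore expected to give 9.47 in this assay, with a likely range from 9.2 to 9.75.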

Compound 4, acid dissociation constant: 9.47
The estimate for compound 4 equals the measured number at the digits printed; measured number inside the range.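

In this assay the move to cyclohexyl in place of benzyl on the second core gives no change at the digits printed from compound 3 to compound 4 (within the scatter) and so matches the first core, which gave no change at the digits printed from compound 1 to compound 2 (within the scatter) on the same change, while the other change, 2-hydroxy-3-methoxyphenyl in place of furan-2-yl, gives no change at the digits printed from compound 2 to compound 4 (within the scatter) in the presence of cyclohexyl. The change therefore carried over cleanly between these two cores in this one read-out, but two cores cannot show that it would do so on any other core, nor does a step this small show anything beyond this read-out. Nothing measured here explains why the number stays put.

The compounds shown leave open whether a group of another kind at this place, such as an amine or a carboxylic acid in place of cyclohexyl, would move the number. Going by these compounds, a longer chain in place of cyclohexylmethyl is equally open.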